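The compounds below may be only part of what the source reports. "The series", "measured", "known", "first", "only" and "open" are said of these compounds alone.

Two compounds have so far been run in an ADME assay (liver) for metabolic stability, with Liver microsome (Rattus norvegicus) as the target, read by LC-MS, using microsomes and NADPH, with stated times of 5 min and 60 min, tested at 4 uM; a lower number here means that less of the compound is left, a higher number that more of the compound is left. Compound 1 `Cc1c(OCCCCOCOc2ccc(C(=O)O)cc2)ccc(C(=O)CC2CCCC2)c1O` gives 31% in this assay, the lower of the two numbers on hand. Compound 2 `Cc1c(OCCCCOc2ccc(C(=O)O)cc2F)ccc(C(=O)CC(C)C)c1O` gives 57%, which lies beyond the usual scatter above compound 1. Compound 3 `Cc1cc(C(=O)O)ccc1OCCCCOc1ccc(C(=O)CC2CCCC2)c(O)c1C` has not yet been measured; it differs from compound 1 in one place: 4-carboxy-2-methylphenyl in place of (4-carboxyphenoxy)methyl on an oxygen on a saturated carbon. Among the measured compounds shown here, no step between measured compounds matches this change, so its size is uncertain, but a modest upward move is expected, a number 14 percentage points higher from compound 1 to compound 3 (beyond the scatter) being the estimated step. Compound 3 is accordingly expected to give about 45%, somewhere between 25% and 65%.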

Compound 3, percent of the compound remaining: 59%
For compound 3 the middle estimate is 14 percentage points below the measured one; the measured number falls inside the stated range.
By their numbers in this assay, from the lowest: compound 1; then compounds 2 and 3 (each within the scatter of the next).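

Putting 4-carboxy-2-methylphenyl in place of (4-carboxyphenoxy)methyl on an oxygen on a saturated carbon gives a number 28 percentage points higher from compound 1 to compound 3 (beyond the scatter) in this assay. Among the compounds shown here, this is the first comparison here that differs in one place, and it shows that the group at this position affects how much compound is left. Nothing on hand accounts for the size of this step.

From the compounds shown here alone, the change swaps the whole group, so the part played by its methyl remains open. So does whether a plain 4-carboxyphenyl group or a 4-carbamoyl-2-methylphenyl group would give a similar number.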